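Swapping a Thiophene for an Isothiazole Ring

The source may hold more compounds than are shown below. What is called first, only, known or untested is meant among the compounds shown, and "the series" means these compounds.

Of the compounds shown here, two share one core and have been tested in a functional assay for activation of Alpha-1B adrenergic receptor (Homo sapiens), read by calcium flux; on this read-out lower numbers stand for an effect already at smaller amounts and higher numbers for an effect only at larger amounts of compound. Compound 1 `c1cncc(-c2ccccc2OCC2=NCCN2)c1` carries a pyridin-3-yl group and in this assay compound 1 gives 79.4 nM. Compound 2 `c1csc(-c2ccccc2OCC2=NCCN2)c1` carries a thiophen-2-yl group in the same position, and in this assay compound 2 gives 3.98 nM. Going by the values given here, the step between them, a 20-fold lower number from compound 1 to compound 2 (1.30 log units; beyond the scatter), is the only measured step available, and it places compound 2 at the lowest number of the two, with compound 1 well above it.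

Compound 3 `c1ccc(-c2ccns2)c(OCC2=NCCN2)c1` has not been measured. It differs from compound 2 in one place: 1,2-thiazol-5-yl in place of thiophen-2-yl on an aromatic carbon. Among the compounds with values here, the single measured step shows that exchanging one five-membered or six-membered aromatic group for another in this position can shift the read-out strongly, so a move in either direction is plausible; the change here adds one ring nitrogen, for which no direct comparison exists. A modest rise is expected, a 2.5-fold higher number from compound 2 to compound 3 (0.40 log units; beyond the scatter). For compound 3 the estimate in this assay is 10 nM, within a range from 3 nM to 40 nM.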

Compound 3, half-maximal effective concentration: 12.6 nM
Estimate against measurement, compound 3: 1.3-fold (0.10 log units) below; measured number inside the range.
By their numbers in this assay, from the lowest: compound 2; then compound 3; then compound 1.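

In this assay, the change from thiophen-2-yl to 1,2-thiazol-5-yl gives a 3.2-fold higher number from compound 2 to compound 3 (0.50 log units; beyond the scatter) and so shows that this position responds even when the ring size stays the same and the new group has the same number of heavy atoms, with one ring carbon traded for a ring nitrogen. Set against the six-membered group, the same 1,2-thiazol-5-yl gives a 6.3-fold lower number from compound 1 to compound 3 (0.80 log units; beyond the scatter) in this read-out, which places compound 3 between the other two and shows that a ring nitrogen in the group does not by itself bring the number up to that of compound 1, although this rests on a single six-membered example. No measurement at hand explains why either step has the size it has.

The compounds shown leave open how other five-membered groups on the same aromatic carbon, such as furan-2-yl or 1,3-thiazol-5-yl, would compare with thiophen-2-yl, and how an unsubstituted phenyl ring would compare with pyridin-3-yl. Going by these compounds, it also remains open whether a small addition to the thiophen-2-yl ring, such as a methyl group or a chlorine atom, would move the number further in either direction.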